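Ortho-substituted aryl amides on a pyridazinone core

The source may report more compounds than this note shows. Statements on the series, on what has been measured and on what is new or still open speak of the compounds shown alone.

Compound 1 `Cc1cc(=O)n(-c2ccccc2OC(F)(F)F)nc1C(=O)Nc1ccc(Oc2ncnc3c2ccn3C)cc1`: 5160 nM
Compound 2 `Cc1cc(=O)n(-c2ccc(Br)cc2F)nc1C(=O)Nc1ccc(Oc2ncnc3c2ccn3C)cc1`: 18800 nM
Compound 3 `Cc1ccc(-n2nc(C(=O)Nc3ccc(Oc4ncnc5c4ccn5C)cc3)c(C)cc2=O)cc1`: > 60000 nM

Three amides sharing one core were measured in a functional assay on PC-3 cells (Homo sapiens) for cytotoxicity, read by MTT assay, with a stated time of 72 h; a lower number here means a stronger inhibitor, a higher number a weaker inhibitor. Compound 1, with a 2-(trifluoromethoxy)phenyl on the aromatic nitrogen, gives 5160 nM. Compound 2, with a 4-bromo-2-fluorophenyl in that place, gives 18800 nM, so a 3.6-fold higher number from compound 1 to compound 2 (0.56 log units; beyond the scatter). For compound 3, with a 4-methylphenyl, the value > 60000 nM is only a limit of this assay, not a number (the limit of > 60000 nM in this assay, at which 1 of the 3 values shown sits). Compound 3 therefore stands at the weak end of the set: an at least 11-fold higher number from compound 1 to compound 3 (1.06 log units; beyond the scatter), and an at least 3.1-fold higher number from compound 2 to compound 3 (0.50 log units; beyond the scatter).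

Compound 4 `Cc1cc(=O)n(-c2ccccc2Cl)nc1C(=O)Nc1ccc(Oc2ncnc3c2ccn3C)cc1` has not yet been measured. It differs from compound 3 in one place: 2-chlorophenyl in place of 4-methylphenyl on an aromatic nitrogen. Among the compounds with values here, the steps that bear on this are those from compound 1 and compound 2 to compound 3, where the 4-methylphenyl was the weakest of the three. Compound 4 carries a 2-chlorophenyl, and compound 1, with its 2-(trifluoromethoxy)phenyl, gave the lowest number, so a large drop in number from compound 3 to compound 4 is expected, an at least 7.5-fold lower number from compound 3 to compound 4 (0.87 log units; beyond the scatter). Compound 4 is estimated at 8000 nM, within 2500 nM to 30000 nM.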

Compound 4, half-maximal inhibitory concentration: 16400 nM
For compound 4 the middle estimate is 2.1-fold (0.31 log units) below the measured one; the range from low to high includes it.
By their numbers in this assay, from the lowest: compound 1; then compounds 4 and 2 (each within the scatter of the next). At a limit, above all of these: compound 3.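

In this assay, 2-chlorophenyl in place of 4-methylphenyl on the aromatic nitrogen gives an at least 3.6-fold lower number from compound 3 to compound 4 (0.56 log units; beyond the scatter), a step whose true size stays unknown, as the value for compound 3 is a limit and not a number: the limit of > 60000 nM in this assay, at which 1 of the 4 values shown sits.

A chlorine alone does not reach the level of compound 1, however, since chloro in place of trifluoromethoxy on the aromatic carbon gives a 3.2-fold higher number from compound 1 to compound 4 (0.50 log units; beyond the scatter), so among these two 2-substituted phenyl groups the identity of the substituent changes the result. The extra bromine and the exchange of chlorine for fluorine in the 4-bromo-2-fluorophenyl of compound 2 leave no difference that can be read, with a 1.1-fold lower number from compound 2 to compound 4 (0.06 log units; within the scatter).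

The compounds shown leave open where an unsubstituted phenyl, a 2-methoxyphenyl or a 2-methylphenyl would fall, and so whether the trifluoromethoxy group of compound 1 is matched by any simpler group on that ring. They also leave open whether a more polar group there, such as a 2-aminophenyl or a 2-carboxyphenyl, would be tolerated at all.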